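This account rests on a few compounds, and the source may have more. Where it says the series, first, only, none or still open, it means among the compounds named here.

Compound 2 `COc1cc(C/N=C(\S)NCC(COC(=O)C(C)(C)C)Cc2ccc(C)c(C)c2)ccc1NS(C)(=O)=O` gives 22 nM in a functional assay on CHO cells with transient receptor potential cation channel subfamily V member 1 (Rattus norvegicus) as the target; a higher number here means that more compound is needed for the effect, a lower number that less compound is needed. Compound 3 `COc1cc(C/N=C(\S)NCC(COC(=O)C(C)(C)C)Cc2ccc(C(C)(C)C)cc2)ccc1NS(C)(=O)=O` gives 40 nM in this assay. Compound 1 `Cc1ccc(CC(CN/C(S)=N/Cc2ccc(NS(C)(=O)=O)cc2)COC(=O)c2ccccc2)cc1C` gives 1730 nM in this assay.

Compound 2 stands lowest of these three numbers; compound 3 lies within the scatter of it, while compound 1 lies far beyond. For the measured compounds named here, the one measured step, a 1.8-fold higher number from compound 2 to compound 3 (0.26 log units; within the scatter), changes a different part of the molecule and stays within the scatter. Compound 4 `COc1cc(C/N=C(\S)NCC(COC(=O)c2ccccc2)Cc2ccc(C)c(C)c2)ccc1NS(C)(=O)=O` differs from compound 2 by phenyl in place of tert-butyl on a carbonyl carbon. Going by the values given here, no measured step covers this change directly; compound 1 also carries a benzoyl group but differs from compound 4 in a further place, so its high number cannot be read as the effect of this change alone. The step of a 3.6-fold higher number from compound 2 to compound 4 (0.56 log units; beyond the scatter) is therefore expected with little confidence, leaning toward a higher number. Compound 4 is expected to give 80 nM, within a range from 15 nM to 400 nM.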

Compound 4, half-maximal effective concentration: 166 nM
The estimate for compound 4 lay 2.1-fold (0.32 log units) below the measured number, within the range that was stated.
By their numbers in this assay, from the lowest: compounds 2 and 3 (each within the scatter of the next); then compound 4; then compound 1.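

The group on the carbonyl carbon matters in this assay: phenyl in place of tert-butyl gives a 7.5-fold higher number from compound 2 to compound 4 (0.88 log units; beyond the scatter), whereas the earlier step, in another part of the molecule, stayed within the scatter. With the benzoyl group held constant, methoxy in place of hydrogen on an aromatic carbon gives a 10-fold lower number from compound 1 to compound 4 (1.02 log units; beyond the scatter), so the wide gap between compound 1 and compound 2 spans both changes. Nothing available explains why either change moves the number.

On these data alone, whether methyl or cyclohexyl on that carbonyl carbon would give a number nearer compound 2 or compound 4 remains open.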